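Dropping the chlorines from the styryl end of compound 1

A few compounds are considered here, and "the series" means these few. Any claim that something is new, unique, unknown or untested is made for them only; others in the source may bear on it.

Measured so far:
- compound 1, `COC(=O)/C=C/c1cccc(N(Cc2ccc(/C=C/c3c(Cl)cccc3Cl)cc2)C(=O)C(C)C)c1`: 195 nM
- compound 2, `CC(C)(C)OC(=O)/C=C/c1ccc(CN(C(=O)C2CCCCC2)c2cccc(/C=C/C(=O)OC(C)(C)C)c2)cc1`: > 1000 nM (a limit of the assay, not a number)
- compound 3, `COC(=O)/C=C/c1cccc(N(Cc2ccc(/C=C/c3c(Cl)cccc3Cl)cc2)C(=O)C2CCCCC2)c1`: 150 nM

In an assay on isolated protein with Bile acid receptor (Homo sapiens) as the target (on this read-out lower numbers stand for an effect already at smaller amounts and higher numbers for an effect only at larger amounts of compound), compound 1 gives the higher of the two numbers shown, and its nearest neighbour is compound 3, reached by a 1.3-fold lower number from compound 1 to compound 3 (0.11 log units; within the scatter) through cyclohexyl in place of isopropyl on a carbonyl carbon. Among the measured compounds shown here, compound 2 stands at a limit, (the limit of > 1000 nM in this assay, at which 1 of the 3 values shown sits), and differs from compound 1 in more than one place, so its limit shows only that no number was reached for it.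

Compound 4, `COC(=O)/C=C/c1cccc(N(Cc2ccc(/C=C/c3ccccc3)cc2)C(=O)C(C)C)c1`, is the next question. It differs from compound 1 by phenyl in place of 2,6-dichlorophenyl on a double-bonded chain carbon bound to a double-bonded chain carbon. For the measured compounds named here, no measured step touches this part of the molecule: the only step with a number, from compound 1 to compound 3, changes the group on the carbonyl carbon and stays within the scatter. The estimate therefore rests on compound 1 alone. Compound 4 is expected to give about 450 nM in this assay, from 150 nM to 1500 nM, an expected shift of a 2.3-fold higher number from compound 1 to compound 4 (0.36 log units; beyond the scatter) whose direction is uncertain.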

Compound 4, half-maximal effective concentration: 65 nM
Estimate against measurement, compound 4: 6.9-fold (0.84 log units) above; the whole stated range lies above it.
By their numbers in this assay, from the lowest: compound 4; then compounds 3 and 1 (each within the scatter of the next). At a limit, above all of these: compound 2.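

In this assay, the end of the molecule carrying the 2,6-dichlorophenyl group proves to be a place where a change moves the number: putting phenyl there gives a 3.0-fold lower number from compound 1 to compound 4 (0.48 log units; beyond the scatter). The only earlier step that can be read, a 1.3-fold lower number from compound 1 to compound 3 (0.11 log units; within the scatter), changes the group on the carbonyl carbon and stays within the scatter, so this is the first single change shown to go beyond it, and it also shows that the two chlorines are not needed for a number in this range. Nothing given here bears on why removing the chlorines lowers the number.

The compounds shown leave open whether a single chlorine, a methyl group or a methoxy group on this phenyl ring would lower or raise the number, and whether a pyridine ring could take the place of the phenyl. Also open is whether the same change would lower the number in compound 3, which carries cyclohexyl on the carbonyl carbon, since the step is shown only with isopropyl there.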